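The compounds below may be only part of what the source reports. "The series", "measured", "known", "first", "only" and "open" are said of these compounds alone.

Working notes on the shared core of compound 1 `NCC[C@@H]1CCOC(c2ccccc2)(c2ccccc2)O1`. In an assay for displacement of a labelled ligand from Sigma non-opioid intracellular receptor 1 (Cavia porcellus), read by scintillation counting (a lower number here means a stronger inhibitor, a higher number a weaker inhibitor), compound 1 reaches only the assay limit, > 10000 nM. Compound 2 `CNCC[C@@H]1CCOC(c2ccccc2)(c2ccccc2)O1` differs by a methyl in place of hydrogen on the amine nitrogen. In this assay compound 2 likewise gives only a limit, > 10000 nM. The step that the two limits leave unreadable from compound 1 to compound 2 therefore cannot be read, since both values sit at the limit of > 10000 nM in this assay, at which 2 of the 2 values shown sit. Compound 3 `CN(C)CC[C@@H]1CCOC(c2ccccc2)(c2ccccc2)O1` repeats that change once more: methyl in place of hydrogen on an amine nitrogen, methylamino to dimethylamino. Among the measured compounds shown here, only one measured step bears on this move, and it is unreadable, so neither direction nor size can be drawn from it for this assay. With both neighbours at the limit, compound 3 is expected to return a further limit rather than a number, and the step that the limit leaves unreadable from compound 2 to compound 3 is an estimate without support from any readable step. Compound 3 is estimated at 15000 nM, between 3000 nM and 60000 nM.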

Compound 3, inhibition constant: 660 nM
The estimate for compound 3 lay 23-fold (1.36 log units) above the measured number; measured number below the stated range.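

In this assay, the change from methylamino to dimethylamino gives an at least 15-fold lower number from compound 2 to compound 3 (1.18 log units; beyond the scatter), the first readable effect of any change on this amine nitrogen. Dimethylamino in place of amino on the same saturated chain carbon gives an at least 15-fold lower number from compound 1 to compound 3 (1.18 log units; beyond the scatter), so with two methyl groups on the nitrogen compound 3 gives a number, while with one methyl compound 2 stays at the limit. Both sizes are lower bounds only, and the steps between the limit values cannot be read: the limit of > 10000 nM in this assay, at which 2 of the 3 values shown sit.

The compounds shown leave open whether larger groups on this nitrogen, such as diethylamino or a piperidine in place of dimethylamino, would keep or lose the number seen for compound 3. They also leave open how a longer chain, such as 3-(dimethylamino)propyl in place of 2-(dimethylamino)ethyl, would read in this assay.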